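From Methyl to Methoxy on a Shared Core

The source may report more compounds than this note shows. Statements on the series, on what has been measured and on what is new or still open speak of the compounds shown alone.

Values in a functional assay on CEM-DNR cells (Homo sapiens), read by MTT assay, with a stated time of 3 days; on this read-out higher numbers stand for weaker inhibition and lower numbers for stronger inhibition:
- Compound 1 `Nc1ncnc2[nH]cc(Sc3cccs3)c12`: 20300 nM
- Compound 2 `c1csc(Sc2c[nH]c3ncnc(-c4cccs4)c23)c1`: 17700 nM
- Compound 3 `Cc1ncnc2[nH]cc(Sc3cccs3)c12`: > 50000 nM

Compound 3 gives > 50000 nM, which is a limit and not a number. Compound 4 `COc1ncnc2[nH]cc(Sc3cccs3)c12` carries methoxy in place of methyl on an aromatic carbon. Two measured steps lead to the methyl group of compound 3: amino to methyl gave an at least 2.4-fold higher number from compound 1 to compound 3 (0.39 log units; beyond the scatter), and thiophen-2-yl to methyl gave an at least 2.8-fold higher number from compound 2 to compound 3 (0.45 log units; beyond the scatter). Between amino and thiophen-2-yl, the data show a 1.1-fold lower number from compound 1 to compound 2 (0.06 log units; within the scatter). Both changes to methyl raised the number, so replacing that methyl is expected to give a modest move to a lower number in this assay. The expected step is an at least 1.6-fold lower number from compound 3 to compound 4 (0.22 log units; that floor lies within the scatter). Compound 4 is estimated at 30000 nM, with an expected range of 12000 nM to 60000 nM.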

Compound 4, half-maximal inhibitory concentration: > 50000 nM
Compound 4: only a limit was reported; the forecaster's own chance of this, stated with the estimate: 40%; at least 1.6-fold (0.22 log units) between middle value and limit.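

In this assay, methoxy in place of amino gives an at least 2.4-fold higher number from compound 1 to compound 4 (0.39 log units; beyond the scatter), and methoxy in place of thiophen-2-yl gives an at least 2.8-fold higher number from compound 2 to compound 4 (0.45 log units; beyond the scatter). Methyl is therefore no longer the only group at this position that falls on the weak side of amino and thiophen-2-yl. Compound 3 and compound 4 both stand at a limit, so the step between them cannot be read: the limit of > 50000 nM in this assay, at which 2 of the 4 values shown sit.

From the compounds shown here alone, how far past that limit compound 3 and compound 4 lie stays open. So does whether a methylamino or dimethylamino group here would match compound 1.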